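A few compounds are considered here, and "the series" means these few. Any claim that something is new, unique, unknown or untested is made for them only; others in the source may bear on it.

Measured so far:
compound 1, `Cc1ccc(-n2nncc2CN2C(=O)C3(C(C#N)=C(N)Oc4c3c3nc5ccccc5nc3c3ccccc43)c3ccccc32)c(C)c1`: > 50000 nM
compound 2, `N#CC1=C(N)Oc2c(N)cc3nc4ccccc4nc3c2C12C(=O)N(Cc1cnnn1-c1cccc(Br)c1)c1ccccc12`: > 50000 nM

In a functional assay on MCF7 cells (Homo sapiens) for antiproliferative activity, read by MTT assay, with a stated time of 48 h (a higher number here means a weaker inhibitor, a lower number a stronger inhibitor), compound 1 gives only a limit, > 50000 nM, and not a number. In this assay compound 2 likewise gives only a limit, > 50000 nM. Within the data shown here, compound 2 therefore stands exactly where every value shown stands, at the limit of > 50000 nM in this assay, at which 2 of the 2 values shown sit; no measured step between the two compounds exists, so how the shared core responds to a change of the aryl group on the aromatic nitrogen is unknown.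

Compound 3, `N#CC1=C(N)Oc2c(N)cc3nc4ccccc4nc3c2C12C(=O)N(Cc1cnnn1-c1ccc([N+](=O)[O-])cc1)c1ccccc12`, differs from compound 2 by 4-nitrophenyl in place of 3-bromophenyl on an aromatic nitrogen. Among the measured compounds shown here, with no step of this kind measured, the expected change is none beyond the scatter, a step that the limit leaves unreadable from compound 2 to compound 3. Compound 3 is thus expected to give about 70000 nM in this assay, within 20000 nM to 250000 nM, most probably reported again only as a limit.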

Compound 3, half-maximal inhibitory concentration: > 50000 nM
Compound 3 was reported as a limit (the forecaster's own chance of this, stated with the estimate: 80%); the middle value lies beyond the limit too.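

In this assay compound 3 gives only a limit, > 50000 nM, and compound 2 gives a limit too, so no step can be read between compound 2 and compound 3. The compounds shown leave open whether any aryl group on the aromatic nitrogen gives the shared core a numerical value in this assay.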